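Swapping Bromo for a Tetrazole Ring

The source may report more compounds than this note shows. Statements on the series, on what has been measured and on what is new or still open speak of the compounds shown alone.

For the measured compounds named here, compound 1 `CCC(C)n1ncn(-c2ccc(N3CCN(c4ccc(OC[C@@H]5CO[C@@](CBr)(c6ccc(Cl)cc6Cl)O5)cc4)CC3)cc2)c1=O` gives 569 nM in a functional assay on HUVEC cells (Homo sapiens), read by scintillation counting and thymidine incorporation, with a stated time of 24 h (on this read-out higher numbers stand for weaker inhibition and lower numbers for stronger inhibition), the highest of the two numbers measured so far. Compound 2 `CCC(C)n1ncn(-c2ccc(N3CCN(c4ccc(OC[C@@H]5CO[C@@](Cn6cnc(C)n6)(c6ccc(Cl)cc6Cl)O5)cc4)CC3)cc2)c1=O` gives 272 nM in this assay. Going by the values given here, the one measured step, which also replaces bromo at the same place, is a 2.1-fold lower number from compound 1 to compound 2 (0.32 log units; beyond the scatter). Compound 3 `CCC(C)n1ncn(-c2ccc(N3CCN(c4ccc(OC[C@@H]5CO[C@@](Cn6cnnn6)(c6ccc(Cl)cc6Cl)O5)cc4)CC3)cc2)c1=O` differs from compound 1 by 1H-tetrazol-1-yl in place of bromo on a saturated chain carbon bound to a saturated ring carbon. A modest drop is expected for compound 3, as a 1.6-fold lower number from compound 1 to compound 3 (0.21 log units; within the scatter), because the comparable step gave a 2.1-fold lower number from compound 1 to compound 2 (0.32 log units; beyond the scatter). Compound 3 is therefore estimated at 350 nM, with a range from 150 nM to 800 nM.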

Compound 3, half-maximal inhibitory concentration: 73 nM
Compound 3: middle estimate off by 4.8-fold (0.68 log units), on the high side, and the stated range ends above it.
By their numbers in this assay, from the lowest: compound 3; then compound 2; then compound 1.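

In this assay, 1H-tetrazol-1-yl in place of bromo gives a clearly larger change (a 7.8-fold lower number from compound 1 to compound 3 (0.89 log units; beyond the scatter)) than the earlier swap, and it also improves on the methyl-bearing triazole (a 3.7-fold lower number from compound 2 to compound 3 (0.57 log units; beyond the scatter)). The outcome at this position therefore depends on which five-membered aromatic ring enters, not only on bromo leaving. No measurement here explains the difference between these groups. Compound 2 and compound 3 differ in both the methyl group and the ring atoms, so the compounds shown cannot separate these two changes. Nor do they show how a plain 1H-1,2,4-triazol-1-yl or an amine would behave at this carbon.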